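Cytotoxicity of a Cyano Analogue Near the Assay Limit

A few compounds are considered here, and "the series" means these few. Any claim that something is new, unique, unknown or untested is made for them only; others in the source may bear on it.

Compound 1, `O=c1n(Cc2cc3cc(Cl)ccc3n2CCCCF)c2cnccc2n1C1CC1`: > 50000 nM
Compound 2, `CS(=O)(=O)CCCn1c(Cn2c(=O)n(C3CC3)c3ccncc32)nc2nc(Cl)ccc21`: > 50000 nM

In an ADME assay on HeLa cells (Homo sapiens) for cytotoxicity, read by ATP content, with a stated time of 3 days (a higher number here means that more compound is tolerated, a lower number that less compound is tolerated), compound 1 gives > 50000 nM, which is a limit of the assay rather than a measured number. Compound 2 likewise gives > 50000 nM, again only a limit. Within the data shown here, compound 1 therefore stands at a limit, and the one other value shown is a limit too: the limit of > 50000 nM in this assay, at which 2 of the 2 values shown sit.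

Compound 3 is `N#CCCCn1c(Cn2c(=O)n(C3CC3)c3ccncc32)cc2cc(Cl)ccc21`. It differs from compound 1 in a single place: cyano in place of fluoromethyl on a saturated chain carbon, three bonds along the chain from an aromatic nitrogen. Fluoromethyl leaves and cyano enters, on a saturated chain carbon, three bonds along the chain from an aromatic nitrogen. Among the measured compounds shown here, no step between measured compounds is recorded here. In this assay no change beyond the usual scatter is expected, so the estimated step that the limit leaves unreadable from compound 1 to compound 3 should be small, in no particular direction. Compound 3 is accordingly expected to give about 60000 nM, between 20000 nM and 200000 nM, most likely reported again as a limit, because compound 1 gives > 50000 nM.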

Compound 3, half-maximal cytotoxic concentration: > 50000 nM
Compound 3 ended at the assay's limit; the forecaster's own chance of this, stated with the estimate: 85%; the middle value does not contradict the limit.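

The step from compound 1 to compound 3 cannot be read in this assay, since each compound gives only a limit and not a number. The compounds shown leave open what cytotoxic concentration any of them has, and whether cyano in place of fluoromethyl alters it: the limit of > 50000 nM in this assay, at which 3 of the 3 values shown sit.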